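From hydroxy to propoxy on compound 2

The source may report more compounds than this note shows. Statements on the series, on what has been measured and on what is new or still open speak of the compounds shown alone.

In an ADME assay on RAW264.7 cells (Mus musculus) for cytotoxicity, read by MTT assay, with a stated time of 24 h, in the absence of a further agent (a lower number here means a stronger inhibitor, a higher number a weaker inhibitor), compound 1 `O=C1OC(Cc2nc(-c3ccccc3)no2)c2ccccc21` gives > 40000 nM, which is a limit of the assay and not a number. Compound 2 `COc1cc(OC)c2c(c1)C(C(O)c1ccc(O)cc1)OC2=O` gives > 40000 nM in this assay, which is also only a limit. So compound 2 has no exact value, and nothing shows how far it lies from the limit.

Compound 3 `CCCOc1ccc(C(O)C2OC(=O)c3c(OC)cc(OC)cc32)cc1` keeps the structure of compound 2 except for one change, propyl in place of hydrogen on an oxygen on an aromatic ring, or hydroxy to propoxy. Going by the values given here, no measured pair of compounds shows what a change like this does in this assay. The expected change is therefore none beyond the usual scatter, and the estimated step runs a number no higher from compound 2 to compound 3 (the limit leaves the size open). Compound 3 is expected to give about 40000 nM, with an estimated range from 15000 nM to 80000 nM.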

Compound 3, half-maximal inhibitory concentration: > 40000 nM
Compound 3 ended at the assay's limit; the forecaster's own chance of this, stated with the estimate: 70%; the middle value sits exactly at the limit.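

No step can be read from compound 2 to compound 3, since in this assay each of them stops at a limit of the assay and not a number: the limit of > 40000 nM in this assay, at which 3 of the 3 values shown sit.

The compounds shown leave open how far any of them lies from that limit, and so what hydroxy to propoxy does here.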